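The source may hold more compounds than are shown below. What is called first, only, known or untested is meant among the compounds shown, and "the series" means these compounds.

In a functional assay on RAW264.7 cells (Mus musculus) for inhibition, read by microscopy, with a stated time of 4 days, in the presence of a further agent that is not named here (on this read-out higher numbers stand for weaker inhibition and lower numbers for stronger inhibition), three compounds with a shared core have been read: compound 1 (`O=C(Nc1ccc(Cl)cc1F)c1cc(Cl)ccc1O`) gives 2120 nM, compound 2 (`O=C(Nc1ccc(I)cc1F)c1cc(F)ccc1O`) gives 1570 nM and compound 3 (`O=C(Nc1ccc(I)cc1F)c1cc(Br)ccc1O`) gives 1930 nM. Compound 3 thus stands within the scatter of both other compounds. Compound 4 (`O=C(Nc1ccc(I)cc1F)c1cc(Cl)ccc1O`) carries one change from compound 3: chloro in place of bromo on an aromatic carbon. Among the measured compounds shown here, the one measured step at this place, a 1.2-fold higher number from compound 2 to compound 3 (0.09 log units; within the scatter), stayed within the scatter, so no step beyond the scatter is expected in this assay. The expected step, a 1.1-fold lower number from compound 3 to compound 4 (0.03 log units; within the scatter), is accordingly small and without a firm direction. Compound 4 is estimated at 1800 nM (expected range 1050 nM to 3100 nM).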

Compound 4, half-maximal inhibitory concentration: 1840 nM
The estimate for compound 4 lay 1.0-fold (0.01 log units) below the measured number; the range from low to high includes it.
By their numbers in this assay, from the lowest: compounds 2, 4, 3 and 1 (each within the scatter of the next).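

In this assay, fluoro, chloro and bromo have now all been read at the place para to a hydroxy group, and the steps of a 1.0-fold lower number from compound 3 to compound 4 (0.02 log units; within the scatter) and a 1.2-fold higher number from compound 2 to compound 4 (0.07 log units; within the scatter) both stay within the scatter, so these three groups cannot be told apart here. The step of a 1.2-fold lower number from compound 1 to compound 4 (0.06 log units; within the scatter) adds iodo in place of chloro at a second place, and it too stays within the scatter. No evidence is available to explain these results. On these data alone, whether an amine, a carboxylic acid or a methoxy group at the place para to a hydroxy group would give a step beyond the scatter remains open.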